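This account rests on a few compounds, and the source may have more. Where it says the series, first, only, none or still open, it means among the compounds named here.

Measured compounds in an assay on isolated protein for binding affinity to Gonadotropin-releasing hormone receptor (Homo sapiens); on this read-out lower numbers stand for stronger inhibition and higher numbers for weaker inhibition: compound 1 `Cc1cc2c(cc1Cc1ccc(C(=O)NC[C@H]3CC[C@H](C(=O)O)CC3)o1)C(C)(C)CCC2(C)C` gives 250 nM; compound 2 `Cc1cc2c(cc1Cc1ccc(C(=O)NCc3ccccc3)o1)C(C)(C)CCC2(C)C` gives 102 nM.

Compound 2 stands at the lower of the two numbers, with compound 1 above it by a 2.5-fold lower number from compound 1 to compound 2 (0.39 log units; beyond the scatter). Compound 3 `Cc1cc2c(cc1Cc1ccc(C(=O)NCC3CCC(CN)CC3)o1)C(C)(C)CCC2(C)C` differs from compound 2 by 4-(aminomethyl)cyclohexyl in place of phenyl on a saturated chain carbon bound to an amide-type nitrogen. Going by the values given here, the only step that bears on it is the one a 2.5-fold lower number from compound 1 to compound 2 (0.39 log units; beyond the scatter), which replaced a substituted cyclohexyl by phenyl; compound 3 reverses that direction, returning to a substituted cyclohexyl. A step of about that size back toward a higher number is therefore expected in this assay, a 2.5-fold higher number from compound 2 to compound 3 (0.39 log units; beyond the scatter). Compound 3 is estimated at 250 nM, range 100 nM to 650 nM.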

Compound 3, inhibition constant: 42 nM
For compound 3 the middle estimate is 6.0-fold (0.77 log units) above the measured one; the measured number lies below the stated range.
By their numbers in this assay, from the lowest: compound 3; then compound 2; then compound 1.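

In this assay, a substituted cyclohexyl on a saturated chain carbon bound to an amide-type nitrogen can outdo phenyl, with a 2.4-fold lower number from compound 2 to compound 3 (0.39 log units; beyond the scatter). With the cyclohexyl kept, the group it carries matters, with a 6.0-fold lower number from compound 1 to compound 3 (0.77 log units; beyond the scatter). The higher number of compound 1 therefore does not extend to every substituted cyclohexyl.

No evidence on the cause of either step is available. From the compounds shown here alone, whether the gain over compound 2 follows the aminomethyl group or the saturated ring stays open; plain cyclohexyl and 4-(aminomethyl)phenyl would separate the two.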